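Replacing 3-chlorophenyl with 4-hydroxyphenyl on compound 3

This account rests on a few compounds, and the source may have more. Where it says the series, first, only, none or still open, it means among the compounds named here.

Among the measured compounds shown here, in a functional assay on EOL1 cells (Homo sapiens) for inhibition, read by fluorescence, with a stated time of 72 h (a lower number here means a stronger inhibitor of growth, a higher number a weaker inhibitor of growth), compound 3 (`CC(C)CCn1cnc2c(Nc3cccc(Cl)c3)nc(N[C@H]3CC[C@H](N)CC3)nc21`) gives 60 nM as the lowest of three numbers so far, while compound 1 (`COc1cc(Nc2nc(N[C@H]3CC[C@H](N)CC3)nc3c2ncn3CCC(C)C)cc(OC)c1`) gives 140 nM and compound 2 (`CCCCCCn1cnc2c(Nc3ccc(O)cc3)nc(N[C@H]3CC[C@H](N)CC3)nc21`) gives 190 nM in the same test. Compound 4 (`CC(C)CCn1cnc2c(Nc3ccc(O)cc3)nc(N[C@H]3CC[C@H](N)CC3)nc21`) carries 4-hydroxyphenyl in place of 3-chlorophenyl on a nitrogen on an aromatic ring. For the measured compounds named here, only one measured step changes this same place: 3-chlorophenyl came in for 3,5-dimethoxyphenyl, a modest change (a 2.3-fold lower number from compound 1 to compound 3 (0.37 log units; beyond the scatter)). Compound 2 already bears 4-hydroxyphenyl on a different chain, and its 190 nM stands higher than the number for compound 3. Going by the values given here, no measured pair isolates the swap itself, so the expectation is loose: a modest step to a higher number in this assay seems likely. The expected change is a 2.8-fold higher number from compound 3 to compound 4 (0.45 log units; beyond the scatter) in this test. Compound 4 is therefore estimated at about 170 nM with an expected range from 60 nM to 480 nM in this test.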

Compound 4, concentration for 50% growth inhibition: 30 nM
The estimate for compound 4 lay 5.7-fold (0.75 log units) above the measured number, outside the stated range (below it).
By their numbers in this assay, from the lowest: compounds 4 and 3 (each within the scatter of the next); then compounds 1 and 2 (each within the scatter of the next).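

In this assay, putting 4-hydroxyphenyl in place of 3-chlorophenyl gives a 2.0-fold lower number from compound 3 to compound 4 (0.30 log units; within the scatter) and so does not separate the two groups, even though only 4-hydroxyphenyl carries a hydrogen-bond donor and acceptor. The same position is not indifferent to its group, since 4-hydroxyphenyl in place of 3,5-dimethoxyphenyl gives a 4.7-fold lower number from compound 1 to compound 4 (0.67 log units; beyond the scatter) in this test. With 4-hydroxyphenyl held fixed, the chain also counts: isopropyl in place of butyl on a saturated chain carbon gives a 6.3-fold lower number from compound 2 to compound 4 (0.80 log units; beyond the scatter) as a step beyond the scatter.

No measurement shown explains any of these steps. Also open, as far as these compounds go, is how an amine or a carboxylic acid on the phenyl ring in place of the hydroxyl, or a shorter chain such as ethyl, would read in this test.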